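The source may report more compounds than this note shows. Statements on the series, on what has been measured and on what is new or still open speak of the compounds shown alone.

Measured in a functional assay on HEY cells (Homo sapiens) for cytotoxicity, read by MTT assay, with a stated time of 72 h; on this read-out higher numbers stand for weaker inhibition and lower numbers for stronger inhibition:

- compound 1 `COc1cccc(CNC(=O)c2nc(Br)c3cccnc3c2N[C@H]2CC[C@H](N)CC2)c1`: 7000 nM
- compound 2 `N[C@H]1CC[C@H](Nc2c(C(=O)NCc3ccc(F)cc3)nc(Br)c3cccnc23)CC1`: "not determined" (no result reported)
- compound 3 `N[C@H]1CC[C@H](NC(=O)c2nc(Br)c3cccnc3c2NCc2ccc(F)cc2)CC1`: 7100 nM

Compound 2 is the starting point here, yet it has no place on the numerical scale: this assay gives no result for it, so it cannot be called stronger or weaker than its neighbours. Among the measured compounds shown here, the only numbers nearby come from two related compounds. Compound 1 gives 7000 nM and compound 3 gives 7100 nM, and these two values lie within the usual scatter of each other.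

The next compound to be tested is compound 4 `CN(C)c1ccc(CNC(=O)c2nc(Br)c3cccnc3c2N[C@H]2CC[C@H](N)CC2)cc1`. It keeps the shared core of compound 2 and changes one group on the benzyl part of the molecule: dimethylamino in place of fluoro on an aromatic carbon. In words, dimethylamino stands in place of fluoro on an aromatic carbon, turning 4-fluorobenzyl into 4-(dimethylamino)benzyl.

With no number for compound 2, no measured starting value exists for this change, and its effect has to be judged indirectly. Compound 1, which also carries a substituted benzyl amide, gives 7000 nM, so compound 4 is expected to fall near that level, with no step beyond the scatter in this assay and no favoured direction. For compound 4 the estimated value is 6000 nM, with an expected range of 2000 nM to 18000 nM.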

Compound 4, half-maximal inhibitory concentration: 5300 nM
The estimate for compound 4 lay 1.1-fold (0.05 log units) above the measured number; the range from low to high includes it.
By their numbers in this assay, from the lowest: compounds 4, 1 and 3 (each within the scatter of the next).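

In this assay, among the compounds shown here, the one step that can be read here is a 1.3-fold lower number from compound 1 to compound 4 (0.12 log units; within the scatter), and it gives the first comparison between two compounds that differ only in the aryl group of the benzyl amide. Replacing 3-methoxyphenyl with 4-(dimethylamino)phenyl changes both the substituent and where it sits on the ring, yet the result stays within the scatter, so these two groups cannot be told apart in this assay. Steps from compound 2 cannot be read because it has no number, so the size of the change from fluoro to dimethylamino remains unknown.

Since compound 1 and compound 4 differ in both substituent and ring position, the effects of those two differences cannot be separated, and nothing available explains the result. On these data alone, it also remains open whether a plain phenyl ring, or a carboxylic acid or morpholine on the same ring, would move the number beyond the scatter, or whether this part of the molecule has little bearing on the read-out.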